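Allyl for Ethyl on the Amine of Compound 2

A few compounds are considered here, and "the series" means these few. Any claim that something is new, unique, unknown or untested is made for them only; others in the source may bear on it.

Compound 1 `CCOc1ccc(NC(=O)c2c(N)n[nH]c2NC)cc1` — 31000 nM
Compound 2 `CCN/C(SC)=C(/C#N)C(=O)Nc1ccc(OCC)cc1` — 41600 nM

Within the data shown here, in a functional assay on PANC-1 cells (Homo sapiens) for cytotoxicity, read by resazurin assay, with a stated time of 48 h (on this read-out higher numbers stand for weaker inhibition and lower numbers for stronger inhibition), compound 2 gives 41600 nM, the higher of the two numbers measured so far. In this assay compound 1 gives 31000 nM, and the two values lie within the usual scatter of each other, so no order between compound 1 and compound 2 can be read from them. Compound 3 `C=CCN/C(SC)=C(/C#N)C(=O)Nc1ccc(OCC)cc1` differs from compound 2 in one place: vinyl in place of methyl on a saturated chain carbon bound to an amine nitrogen. Among the measured compounds shown here, no measured pair differs in this way, so nothing in the data shows how this assay answers such a change. The expectation is therefore for no step beyond the scatter, in either direction, and compound 3 is expected to give about 38000 nM, within a range from 15000 nM to 95000 nM. The expected step is a 1.1-fold lower number from compound 2 to compound 3 (0.04 log units; within the scatter), essentially flat.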

Compound 3, half-maximal inhibitory concentration: 21800 nM
Estimate against measurement, compound 3: 1.7-fold (0.24 log units) above, and the stated range covers the measured number.
By their numbers in this assay, from the lowest: compounds 3, 1 and 2 (each within the scatter of the next).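

In this assay, among these compounds, the change from ethylamino to allylamino gives a 1.9-fold lower number from compound 2 to compound 3 (0.28 log units; within the scatter) and is the first step seen at this position on the amine. Vinyl in place of methyl on a saturated chain carbon bound to an amine nitrogen therefore adds a carbon and a double bond outside aromatic rings without a shift that can be told apart from the scatter, so no order can be read between these two compounds. The data at hand offer no measured basis for explaining this small step.

Going by these compounds, whether a longer chain, a benzyl group or a hydroxyethyl group on this amine nitrogen would move the number beyond the scatter remains open. This single pair also leaves open how the position responds to any larger change.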